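The source may hold more compounds than are shown below. What is called first, only, known or untested is meant among the compounds shown, and "the series" means these compounds.

Working notes on the series. The shared core of compound 1 `CN(C)c1ccc(-c2cc(C(=O)N[C@H]3CCCNC3)c(NC(N)=O)s2)cc1` carries the 4-(dimethylamino)phenyl group, and in a functional assay on HT-29 cells (Homo sapiens) (a higher number here means that more compound is needed for the effect, a lower number that less compound is needed), compound 1 gives 90 nM. Going by the values given here, that is the only number in hand: compound 2 `NC(=O)Nc1sc(-c2ccccc2)cc1C(=O)NC1CCOCC1` stands in this assay at "not determined" (no result reported), and compound 3 `CN1CCN(C(=O)c2cc(-c3ccccc3)sc2NC(N)=O)CC1` likewise at "not determined" (no result reported), so neither adds a figure to set compound 1 against. Among the compounds with values here, no pair of measured compounds differs in a single place, so no measured step exists in this set.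

Compound 4 `NC(=O)Nc1sc(-c2ccc(Cl)cc2)cc1C(=O)N[C@H]1CCCNC1` differs from compound 1 by the change (chloro in place of dimethylamino on an aromatic carbon). Within the data shown here, with no measured step to guide the size of this change, the expectation is for a step from compound 1 to compound 4 in this assay of modest size, if any, more likely toward more compound being needed than less, and possibly within the scatter. The estimate for the step is a 2.2-fold higher number from compound 1 to compound 4 (0.35 log units; beyond the scatter). Compound 4 is therefore expected in this assay at about 200 nM, within a range from 60 nM to 700 nM.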

Compound 4, half-maximal effective concentration: 40 nM
Beside the measured number, compound 4's estimate is 5.0-fold (0.70 log units) above it; the measured number lies below the stated range.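

In this assay, going by these compounds alone, chloro in place of dimethylamino on an aromatic carbon, para to a large group, gives a 2.3-fold lower number from compound 1 to compound 4 (0.35 log units; beyond the scatter), the first step that can be read in this set and one that shows this position responds to substitution. The dimethylamino group is therefore not required for activity at this level, since the 4-chlorophenyl compound 4 needs less compound for the effect. Nothing available accounts for the direction of this step.

Steps involving compound 2 and compound 3 cannot be read, so the unsubstituted phenyl gives no reference point at this position and the effects of adding chloro and removing dimethylamino cannot be separated. From the compounds shown here alone, whether fluoro, methoxy or a carboxylic acid at this position would follow chloro or dimethylamino remains open.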